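A few compounds are considered here, and "the series" means these few. Any claim that something is new, unique, unknown or untested is made for them only; others in the source may bear on it.

Compound 1, `Cc1c(OCCCCOc2ccc(C(=O)O)cc2)ccc(C(=O)CC2CCCC2)c1O`: 82.6%
Compound 2, `COc1cc(C(=O)O)ccc1OCCCCOc1ccc(C(=O)CC(C)C)c(O)c1C`: 85.7%
Compound 3, `Cc1c(OCCCCOc2ccc(C(=O)O)cc2)ccc(C(=O)CC(C)C)c1O`: 88%

All three compounds share one core and were measured in an assay on HEK293 cells for positive allosteric modulation of metabotropic glutamate receptor 2 (Rattus norvegicus), read by thallium flux, with a stated time of 2.5 min; a higher number here means a larger maximal response, a lower number a smaller maximal response. Compound 3 gives 88%, and the other two lie close to it: the step of a number 5.4 percentage points higher from compound 1 to compound 3 (within the scatter) and the step of a number 2.3 percentage points higher from compound 2 to compound 3 (within the scatter) are both small, so on these numbers the three compounds cannot be told apart. The first of these steps changes the group on the saturated chain carbon bound to the carbonyl carbon, the second removes a methoxy from an aromatic carbon; neither changed the maximal response beyond the scatter.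

Compound 4, `Cc1c(OCCCCOc2ccccc2C(=O)O)ccc(C(=O)CC(C)C)c1O`, has not been measured. It differs from compound 3 in one place: 2-carboxyphenyl in place of 4-carboxyphenyl on an oxygen on a saturated carbon. The carboxylic acid thus stays on the same aromatic ring but sits on a different carbon of it. Among the compounds with values here, no measured step touches this part of the molecule, so the two steps above give no direct guide; they only show that changes elsewhere left this assay's read-out nearly unmoved. The step of a number 8 percentage points lower from compound 3 to compound 4 (within the scatter) is therefore expected to be small, though with more uncertainty than for a change already tested. Compound 4 is expected to give about 80% in this assay, within a range from 55% to 98%.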

Compound 4, largest response reached (reported as percent of maximum), in percent of the reference or control that the assay uses: 92.4%
Beside the measured number, compound 4's estimate is 12.4 percentage points below it; the measured number falls inside the stated range.
By their numbers in this assay, from the lowest: compounds 1, 2, 3 and 4 (each within the scatter of the next).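

Placing the carboxylic acid on a different carbon of the same aromatic ring, with 2-carboxyphenyl in place of 4-carboxyphenyl on an oxygen on a saturated carbon, gives in this assay a number 4.4 percentage points higher from compound 3 to compound 4 (within the scatter). Within the data shown here, this is the first measured change in this part of the molecule, and it shows that the maximal response of these two compounds cannot be told apart whichever of the two carboxyphenyl groups is present, even though the two have the same atoms joined differently. No measurement shown here offers an explanation for this result.

The read-out also concerns only the largest response reached, so this result does not show whether the two carboxyphenyl groups would match on any other measure. All four compounds carry a carboxylic acid and the same chain between their two ether oxygens, which leaves open what a tetrazole or a plain phenyl group would do in place of the carboxyphenyl group, and what a longer chain would do in place of the present one.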